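This account rests on a few compounds, and the source may have more. Where it says the series, first, only, none or still open, it means among the compounds named here.

Compound 1, `O=C(/C=C/c1ccc2c(c1)B(O)OC2)c1ccc(OCc2ccccc2)cc1`, in an ADME assay on L929 cells (Mus musculus) for cytotoxicity, read by resazurin assay, with a stated time of 72 h (a higher number here means a weaker inhibitor, a lower number a stronger inhibitor), gives > 10 ug/mL, which is a limit of the assay rather than a number.
Compound 2, `CSc1ccc(C(=O)/C=C/c2ccc3c(c2)B(O)OC3)cc1`, in this assay gives > 10 ug/mL, again a limit of the assay.
Compound 3, `COc1ccc(C(=O)/C=C/c2ccc3c(c2)B(O)OC3)cc1`, in this assay gives > 10 ug/mL, also a limit of the assay.

Compound 3 therefore stands at the same limit as every other value shown: all three sit at the limit of > 10 ug/mL in this assay, at which 3 of the 3 values shown sit, and none of them is a number.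

The step from compound 3 to compound 4, `O=C(/C=C/c1ccc2c(c1)B(O)OC2)c1ccc([N+](=O)[O-])cc1`, is nitro in place of methoxy on an aromatic carbon. Within the data shown here, this swap at the same position on the ring has no direct precedent. The measured steps that change the group on this aromatic carbon are a step that the two limits leave unreadable from compound 1 to compound 2, a step that the two limits leave unreadable from compound 1 to compound 3 and a step that the two limits leave unreadable from compound 2 to compound 3; each joins two limits, so its size and direction cannot be read. They show only that benzyloxy, methylsulfanyl and methoxy all leave the value at the limit in this assay.

With no readable step on this position, the expected outcome for compound 4 is a step that the limit leaves unreadable from compound 3 to compound 4, that is, no movement beyond the scatter, with the value most likely staying at the limit. Compound 4 is therefore estimated at 15 ug/mL, with a range from 5 ug/mL to 60 ug/mL.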

Compound 4, half-maximal inhibitory concentration: > 10 ug/mL
Compound 4 ended at the assay's limit; the forecaster's own chance of this, stated with the estimate: 80%; the middle value lies beyond the limit too.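

In this assay compound 4 gives > 10 ug/mL, which is a limit of the assay and not a number. The steps joining compound 4 to compound 1, compound 2 and compound 3 therefore cannot be read, and all four compounds stand at the same point: the limit of > 10 ug/mL in this assay, at which 4 of the 4 values shown sit. The compounds shown leave open how far each lies past this limit, and whether changing the group on this aromatic carbon shifts the value at all.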